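The source may report more compounds than this note shows. Statements on the series, on what has been measured and on what is new or still open speak of the compounds shown alone.

Two ureas sharing one core have been measured in an ADME assay on microsomes from liver (Homo sapiens) for metabolic stability, using NADPH, with a stated time of 60 min; a higher number here means faster removal of the compound, a lower number slower removal. Compound 1 `O=C(Nc1ccc(F)c(C(F)(F)F)c1)Nc1ccccn1` gives 188 uL/min in this assay. For the measured compounds named here, compound 2 `Cc1cc(NC(=O)Nc2ccc(F)c(C(F)(F)F)c2)on1` gives 73 uL/min in this assay, the lowest of the two numbers so far; the gap to the other is a 2.6-fold lower number from compound 1 to compound 2 (0.41 log units; beyond the scatter). Compound 3 `O=C(Nc1cccnc1)Nc1ccc(F)c(C(F)(F)F)c1` has not yet been measured. It differs from compound 2 by pyridin-3-yl in place of 3-methyl-1,2-oxazol-5-yl on an amide-type nitrogen. Going by the values given here, the only measured step that bears on this change is a 2.6-fold lower number from compound 1 to compound 2 (0.41 log units; beyond the scatter), where a pyridin-2-yl gave way to the same oxazole and the number fell. Compound 3 undoes that kind of swap, bringing a pyridyl back, though pyridin-3-yl rather than pyridin-2-yl, so an upward step is expected, roughly a 2.1-fold higher number from compound 2 to compound 3 (0.31 log units; beyond the scatter). Compound 3 is therefore expected to give about 150 uL/min in this assay, with a likely range from 75 uL/min to 300 uL/min.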

Compound 3, intrinsic clearance in a liver preparation (reported as CLH), per the amount of preparation that the assay uses: 13 uL/min
Compound 3: the middle estimate sits 12-fold (1.06 log units) above what was measured; the measured number lies below the stated range.
By their numbers in this assay, from the lowest: compound 3; then compound 2; then compound 1.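

In this assay, the group on this amide-type nitrogen matters more than the earlier pair could show. Two pyridyl groups do not behave alike: pyridin-3-yl in place of pyridin-2-yl gives a 14-fold lower number from compound 1 to compound 3 (1.16 log units; beyond the scatter), so the point at which the same ring is attached makes a large difference. The earlier drop with 3-methyl-1,2-oxazol-5-yl therefore did not mean that pyridyl groups as a class give the higher numbers, since pyridin-3-yl in its place gives a 5.6-fold lower number from compound 2 to compound 3 (0.75 log units; beyond the scatter).

Nothing measured here explains why the two pyridyl groups differ so strongly. From the compounds shown here alone, it also remains open whether pyridin-4-yl, or a pyridin-3-yl ring carrying a methyl group or an amine, would give a number as low as that of compound 3.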